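Nitro substitution across two dithiolethione cores

The source may report more compounds than this note shows. Statements on the series, on what has been measured and on what is new or still open speak of the compounds shown alone.

Compound 1 `COc1ccc(-c2ssc(=S)c2-c2cc(OC)c(OC)c(OC)c2)cc1` gives 21100 nM in a functional assay on SGC-7901 cells (Homo sapiens) for antiproliferative activity, read by MTT assay, with a stated time of 72 h; on this read-out higher numbers stand for weaker inhibition and lower numbers for stronger inhibition. Compound 2 `COc1ccc(-c2ssc(=S)c2-c2cc(OC)c(OC)c(OC)c2)cc1[N+](=O)[O-]` gives 13600 nM in this assay. Compound 3 `COc1ccc(-c2c(-c3cc(OC)c(OC)c(OC)c3)ssc2=S)cc1` gives 2350 nM in this assay.

Compound 1 and compound 3 are built from the same atoms joined differently; the difference between the two cores is not broken down here. Compound 3 stands lowest of the three, and its gaps to compound 2 and compound 1 lie beyond the scatter, so it is the strongest inhibitor measured so far.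

On the core of compound 1, the change nitro in place of hydrogen on an aromatic carbon made a 1.6-fold lower number from compound 1 to compound 2 (0.19 log units; within the scatter). Compound 4 `COc1ccc(-c2c(-c3cc(OC)c(OC)c(OC)c3)ssc2=S)cc1[N+](=O)[O-]` carries the same change on the core of compound 3: nitro in place of hydrogen on an aromatic carbon. Going by the values given here, the step from compound 3 to compound 4 is expected to be a 1.6-fold lower number from compound 3 to compound 4 (0.19 log units; within the scatter), resting on a 1.6-fold lower number from compound 1 to compound 2 (0.19 log units; within the scatter) as the only measured instance of this change. Compound 4 is therefore estimated at 1500 nM, with a likely range from 600 nM to 4000 nM.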

Compound 4, half-maximal inhibitory concentration: 44700 nM
For compound 4 the middle estimate is 30-fold (1.47 log units) below the measured one; measured number outside the range, above it.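

In this assay, nitro in place of hydrogen on an aromatic carbon does not carry over from one core to the other: the same change on two cores in this assay, a 1.6-fold lower number (0.19 log units; within the scatter) from compound 1 to compound 2 and a 19-fold higher number (1.28 log units; beyond the scatter) from compound 3 to compound 4, 30-fold (1.47 log units) apart, beyond the scatter of two such steps. On the core of compound 3 the change gave a 19-fold higher number from compound 3 to compound 4 (1.28 log units; beyond the scatter), so a step read on one core cannot stand in for the same step on the other core in this series. Going by these compounds alone, with only one pair on each core, this shows that the outcome differs between these two cores at this one place, ortho to a methoxy group, but it does not show why, nor how other changes would transfer.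

Going by these compounds, whether an amine or a fluorine at the same place would also split between the two cores remains open. On these data alone, it is also open whether a nitro group elsewhere on this ring would follow the core of compound 1 or the core of compound 3.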